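Chloropurine benzyl series: removing a chloro at the core

The source may report more compounds than this note shows. Statements on the series, on what has been measured and on what is new or still open speak of the compounds shown alone.

Within the data shown here, compound 2 `ClCc1cccc(Cn2cnc3c(Cl)nc(Cl)nc32)c1` gives 2510 nM in a functional assay on SF-268 cells (Homo sapiens) for cytotoxicity, read by sulforhodamine B assay, with a stated time of 48 h (a lower number here means a stronger inhibitor of growth, a higher number a weaker inhibitor of growth), the second highest of the three numbers measured so far; compound 3 `Nc1nc(Cl)c2ncn(Cc3ccccc3CCl)c2n1` gives 4680 nM, a gap within the scatter of compound 2, whereas compound 1 `ClCc1ccc(Cn2cnc3c(Cl)ncnc32)cc1` gives 640 nM, a gap beyond the scatter. Compound 4 `ClCc1cccc(Cn2cnc3c(Cl)ncnc32)c1` has not yet been measured. It differs from compound 2 by hydrogen in place of chloro on an aromatic carbon. Among the measured compounds shown here, no single-change step between measured compounds is available to calibrate this, but compound 4 carries the same core as compound 1, and compound 1 gives 640 nM in this assay; on that basis a step toward a lower number, somewhat beyond the scatter, is expected: a 2.5-fold lower number from compound 2 to compound 4 (0.40 log units; beyond the scatter). Compound 4 is therefore estimated at 1000 nM, with a range from 400 nM to 2500 nM.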

Compound 4, concentration for 50% growth inhibition: 3540 nM
Compound 4: middle estimate off by 3.5-fold (0.55 log units), on the low side; measured number outside the range, above it.
By their numbers in this assay, from the lowest: compound 1; then compounds 2, 4 and 3 (each within the scatter of the next).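

In this assay, replacing the chloro between two ring nitrogen atoms with hydrogen gives a 1.4-fold higher number from compound 2 to compound 4 (0.15 log units; within the scatter) as the step, so this pair shows no clear dependence on that chloro. Sharing a core with compound 1 does not bring compound 4 to the same level: compound 1 gives 640 nM and compound 4 gives 3540 nM in this test. No measurement on hand accounts for this result.

From the compounds shown here alone, whether a methoxy group or a nitrile at this position would shift the number beyond the scatter remains open. Also open, going by these compounds, is whether the same change from chloro to hydrogen would give a similar step of compound 1.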